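The compounds below may be only part of what the source reports. "The series", "measured", "known", "first", "only" and "open" are said of these compounds alone.

Compound 1 `Clc1ccccc1Cn1nnc2c(NC3CCC3)nc(-c3ccccc3)nc21`: 24000000 nM
Compound 2 `OCCCNc1nc(-c2ccccc2)nc2c1nnn2Cc1ccccc1`: 21400000 nM
Compound 3 `OCCCNc1nc(-c2ccccc2)nc2c1nnn2Cc1ccccc1F`: 3700000 nM

Three compounds sharing one core were tested in an assay on isolated protein for binding affinity to adenosine receptor A1 (Bos taurus); on this read-out lower numbers stand for stronger inhibition and higher numbers for weaker inhibition. In this assay compound 1 gives 24000000 nM, and compound 2, with 21400000 nM, stands within the usual scatter of that number, so the two cannot be ranked against each other. Compound 3, at 3700000 nM, lies beyond the scatter below both of them. Within the data shown here, the only single-point step among the measured compounds is a 5.8-fold lower number from compound 2 to compound 3 (0.76 log units; beyond the scatter), a change on the benzyl ring that does not touch the amine side of the core.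

Compound 4 `Clc1ccccc1Cn1nnc2c(NC3CCCC3)nc(-c3ccccc3)nc21` has not yet been measured. It differs from compound 1 in one place: cyclopentyl in place of cyclobutyl on a nitrogen on an aromatic ring. Among the measured compounds shown here, no measured step bears on this change, since the one step available concerns a different part of the molecule. With no guidance on ring size at this nitrogen, compound 4 is expected to stay close to compound 1, with a step of a 1.6-fold lower number from compound 1 to compound 4 (0.20 log units; within the scatter) that is unlikely to reach beyond the scatter. The estimate for compound 4 in this assay is therefore 15000000 nM, within a range from 4000000 nM to 50000000 nM.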

Compound 4, inhibition constant: 9000000 nM
Estimate against measurement, compound 4: 1.7-fold (0.22 log units) above, and the stated range covers the measured number.
By their numbers in this assay, from the lowest: compound 3; then compound 4; then compounds 2 and 1 (each within the scatter of the next).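

In this assay, among these compounds, the change from cyclobutyl to cyclopentyl on a nitrogen on an aromatic ring gives the first reading on the amine side of the core, with a 2.7-fold lower number from compound 1 to compound 4 (0.43 log units; beyond the scatter) where the earlier single-place step concerned only the benzyl ring. The step is modest but beyond the scatter, so going from a four-membered to a five-membered carbon ring at this nitrogen does register on this read-out, although compound 4 still stands at 9000000 nM and the number remains very high. Nothing in the data at hand accounts for this difference between the two rings.

As far as these compounds go, two ring sizes make a single step and no trend, so it stays open whether a cyclohexyl group on this nitrogen would carry the number further in the same direction or a cyclopropyl group would move it the other way. Also open, from the compounds shown here alone, is whether the cyclopentylamino group would give a similar step on a core carrying the plain benzyl group or the fluorinated benzyl group in place of the chlorinated one.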